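The source may hold more compounds than are shown below. What is called first, only, known or untested is meant among the compounds shown, and "the series" means these compounds.

Measured compounds:
compound 1 `Nc1ccccc1NC(=O)c1ccc(CSC(=S)N2CCN(Cc3ccccn3)CC2)cc1`: 23.4%
compound 2 `Nc1ccccc1NC(=O)c1ccc(CSC(=S)N2CCCc3ccccc32)cc1`: 38.5%

In a functional assay on MGC-803 cells (Homo sapiens) for antiproliferative activity, read by CCK-8 assay, with a stated time of 72 h, tested at 2 uM (on this read-out lower numbers stand for a weaker effect and higher numbers for a stronger effect at the one concentration tested), compound 1 gives 23.4%, the lower of the two numbers, and compound 2 gives 38.5%, a gap beyond the scatter. Compound 3 `Nc1ccccc1NC(=O)c1ccc(CSC(=S)N2CCN(Cc3ccncc3)CC2)cc1` has not been measured in this assay. It differs from compound 1 by pyridin-4-yl in place of pyridin-2-yl on a saturated chain carbon bound to an amine nitrogen in a ring. For the measured compounds named here, no step between two measured compounds shows how such a change acts, so the account rests on compound 1 alone. For compound 3 a step of a number 1.6 percentage points higher from compound 1 to compound 3 (within the scatter) is expected, one not beyond the scatter. Compound 3 is therefore estimated at 25%, within a range from 10% to 42%.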

Compound 3, a percentage reported as inhibition, at one concentration (the size of the read-out at that concentration, not a potency): 18.4%
The estimate for compound 3 lay 6.6 percentage points above the measured number; low and high end bracket the measured number.
By their numbers in this assay, from the lowest: compounds 3 and 1 (each within the scatter of the next); then compound 2.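

In this assay, for the compounds shown here, pyridin-4-yl in place of pyridin-2-yl on a saturated chain carbon bound to an amine nitrogen in a ring gives a number 5 percentage points lower from compound 1 to compound 3 (within the scatter) and so offers the first direct look at this position. At this place the assay does not separate the two pyridinyl groups. Nothing available explains this result. On these data alone, whether pyridin-3-yl, a plain phenyl or a carboxylic acid at the same place would leave the number unchanged remains open. So does whether the result would hold in other cell lines.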